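Shortening the ester chain toward compound 4

The source may report more compounds than this note shows. Statements on the series, on what has been measured and on what is new or still open speak of the compounds shown alone.

Three esters of one shared core have been tested in a functional assay on Vero cells (Chlorocebus sabaeus) for cytotoxicity; on this read-out lower numbers stand for higher toxicity in this test and higher numbers for lower toxicity in this test. Compound 1, `CCCCCCCCOC(=O)C(O)Cn1cnc2c(N)ncnc21`, carries an octyl ester and gives 200 ug/mL. Compound 2, `CC(C)OC(=O)C(O)Cn1cnc2c(N)ncnc21`, carries an isopropyl ester. In this assay compound 2 gives > 400 ug/mL, which is a limit of the assay rather than a number. Compound 3, `COCCOC(=O)C(O)Cn1cnc2c(N)ncnc21`, carries a 2-methoxyethyl ester. In this assay compound 3 also gives > 400 ug/mL, a limit of the assay. So compound 3 stands at the upper edge of what this assay reports, a position described by the limit of > 400 ug/mL in this assay, at which 2 of the 3 values shown sit.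

Compound 4, `COC(=O)C(O)Cn1cnc2c(N)ncnc21`, is the methyl ester. The change is hydrogen in place of methoxymethyl on a saturated chain carbon bound to an oxygen next to a carbonyl group. The measured steps that bear on it are an at least 2.0-fold higher number from compound 1 to compound 2 (0.30 log units; that floor lies within the scatter) and an at least 2.0-fold higher number from compound 1 to compound 3 (0.30 log units; that floor lies within the scatter): both shortening moves raised the number to the limit, though each step is only a floor. The step that the two limits leave unreadable from compound 2 to compound 3 gives no size. Cutting the chain further is therefore expected to leave the number at or beyond the limit, with no step beyond the scatter. Compound 4 is expected to give 400 ug/mL, within 200 ug/mL to 800 ug/mL. That estimate means a number no higher from compound 3 to compound 4 (the limit leaves the size open), expected to stay within the scatter.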

Compound 4, minimum cytotoxic concentration: > 400 ug/mL
Compound 4: only a limit was reported; the forecaster's own chance of this, stated with the estimate: 80%; the middle value sits exactly at the limit.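

Compound 4 shows that the ester at this position can be cut back to methyl, with hydrogen in place of methoxymethyl, and this assay still reports only a limit for it rather than a number. Among the compounds shown here, the one readable comparison is an at least 2.0-fold higher number from compound 1 to compound 4 (0.30 log units; that floor lies within the scatter), the same floor as seen for the two earlier short esters, so it adds no measured size to the effect of shortening the chain. The steps to compound 4 from compound 2 and from compound 3 cannot be read, and among these esters only compound 1 goes against the grouping at one edge of the read-out: the limit of > 400 ug/mL in this assay, at which 3 of the 4 values shown sit.

As far as these compounds go, because only the octyl ester of compound 1 gives an actual number, it remains open how long the chain must be before a number appears at all, and a butyl or hexyl ester would fall in that gap. From the compounds shown here alone, it also remains open whether a free carboxylic acid or an amide at this position would stay at the same limit, and whether the esters that share the limit differ from one another at all.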